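A few compounds are considered here, and "the series" means these few. Any claim that something is new, unique, unknown or untested is made for them only; others in the source may bear on it.

Compound 1, with the structure `CN(C[C@H]1Cc2c(cccc2N2CCN(C3CC3)CC2)CN1)[C@H]1CCCc2cccnc21`, was tested in an ADME assay on microsomes from liver (Mus musculus) for metabolic stability, read by LC-MS, with a stated time of 10 min (on this read-out lower numbers stand for a less stable compound and higher numbers for a more stable compound), and gives 7%. A second compound from the same series, compound 2 with the structure `c1cnc2c(c1)CCC[C@@H]2N(CC1CCCCC1)C[C@H]1Cc2c(cccc2N2CCNCC2)CN1`, gives 85.6% in this assay. On these two numbers compound 1 stands lowest; its nearest neighbour is compound 2, whose number lies well beyond the usual scatter above it. For the measured compounds named here, no pair of compounds that differ in one place only has been measured, so the effect of a single change has not yet been seen.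

Compound 3, with the structure `CN(C[C@H]1Cc2c(cccc2N2CCN3CCC[C@@H]3C2)CN1)[C@H]1CCCc2cccnc21`, has not been measured. It differs from compound 1 in one place: a group of 9 heavy atoms (7 carbon, 2 nitrogen; one five-membered non-aromatic ring with 1 hetero atom, one six-membered non-aromatic ring with 2 hetero atoms) in place of a group of 9 heavy atoms (7 carbon, 2 nitrogen; one three-membered non-aromatic ring of carbon only, one six-membered non-aromatic ring with 2 hetero atoms), on an aromatic carbon. The group that leaves and the group that enters are both built from the same count of carbon and nitrogen atoms, joined differently, and the methyl on the amine of compound 1 is kept.

For compound 3 the step from compound 1 is expected to be small, a number 8 percentage points higher from compound 1 to compound 3 (within the scatter), upward if anything, and close to the scatter. Compound 3 is therefore expected to give 15% in this assay, within a range from 4% to 40%.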

Compound 3, percent of the compound remaining: 36.7%
Beside the measured number, compound 3's estimate is 21.7 percentage points below it; the measured number falls inside the stated range.
By their numbers in this assay, from the lowest: compound 1; then compound 3; then compound 2.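

In this assay, replacing the 4-cyclopropylpiperazin-1-yl group on an aromatic carbon with a group that holds a five-membered and a six-membered non-aromatic ring gives a number 29.7 percentage points higher from compound 1 to compound 3 (beyond the scatter). This is the one single change shown at this position, and it shows that the read-out can respond to how the atoms of this group are joined, since the group that leaves and the group that enters have the same atoms, the same count of hydrogen-bond acceptors and no net charge. Nothing measured here accounts for the size of this step.

The compounds shown leave open whether the step comes from the ring arrangement itself or depends on the one defined stereocentre of the entering group, a question that the mirror-image form of this group could address. They also leave open how a simpler group at the same carbon, such as 4-methylpiperazin-1-yl or morpholin-4-yl, would read, and whether the same swap would give a similar step with an ethyl group in place of the methyl on the amine.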